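The source may report more compounds than this note shows. Statements on the series, on what has been measured and on what is new or still open speak of the compounds shown alone.

Compound 1 `COC(=O)[C@H](C)[C@H]1CC[C@@](C)(CCC2=C(C)CCCC2(C)C)OO1` gives > 25000 nM in a functional assay on SK-MEL-5 cells (Homo sapiens) for inhibition (on this read-out higher numbers stand for weaker inhibition of growth and lower numbers for stronger inhibition of growth), which is a limit of the assay and not a number.
Compound 2 `C=C1CCCC(C)(C)C1CC[C@]1(C)CC[C@H]([C@@H](C)C(=O)OC)OO1` gives 3940 nM in this assay.
Compound 3 `C=C1CCCC(C)(C)C1CC[C@@]1(C)CC[C@H]([C@@H](C)C(=O)O)OO1` gives 6140 nM in this assay.

Compound 3 holds the higher of the two numbers, but its gap to compound 2 lies within the scatter, so the two cannot be ordered. Compound 1 sits at the limit of > 25000 nM in this assay, at which 1 of the 3 values shown sits.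

Compound 4 `C=C1CCCC(C)(C)C1CC[C@]1(C)CC[C@@H]([C@@H](C)C(=O)O)OO1` differs from compound 3 only in configuration: the two compounds have the same atoms and bonds; at least one stereo element is drawn with a configuration in one of them and without one in the other: 2 of 4 stereo elements differ; a stereocentre at a saturated ring carbon is drawn S in compound 3 and R in compound 4; a stereocentre at a saturated ring carbon is drawn R in compound 3 and S in compound 4. Among the compounds with values here, no measured pair shows what such an inversion does here, so a step of modest size in either direction is expected, most likely none beyond the scatter. Compound 4 is therefore expected to give 6000 nM in this assay, within 2000 nM to 20000 nM, a step of a 1.0-fold lower number from compound 3 to compound 4 (0.01 log units; within the scatter).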

Compound 4, concentration for 50% growth inhibition: > 10000 nM
Compound 4: no number, only a limit; the forecaster's own chance of this, stated with the estimate: 15%; middle value at least 1.6-fold (0.22 log units) away from the limit.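

Compound 4 gives no number in this assay, only a limit of the assay: the limit of > 10000 nM in this assay, at which 1 of the 4 values shown sits. Inverting both stereocentres at saturated ring carbons, with atoms and bonds unchanged, gives an at least 1.6-fold higher number from compound 3 to compound 4 (0.21 log units; that floor lies within the scatter). Within the data shown here, this is the first reading on configuration at these ring carbons, but it is only a floor, so the true size of the step stays unknown.

The compounds shown leave open which of the two stereocentres carries the step. They also leave open whether the same inversion would read alike with a primary amide or a primary alcohol in place of the carboxylic acid.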